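From benzyl to thiophen-2-yl on a shared core

This account rests on a few compounds, and the source may have more. Where it says the series, first, only, none or still open, it means among the compounds named here.

Among the compounds with values here, compound 2 `NC(=O)c1sc2nc(Cc3ccccc3)cc(C(F)(F)F)c2c1N` is the one member of this small set to give a number in an assay on isolated protein for inhibition of LIM domain kinase 1 (Homo sapiens), read by Kinase-Glo, with a stated time of 60 min; a higher number here means a weaker inhibitor, a lower number a stronger inhibitor: compound 2 gives 30000 nM. Compound 1 `NNC(=O)c1sc2ncccc2c1N` reaches only a limit of the assay, and in this assay compound 1 gives > 100000 nM. Compound 3 `NC(=O)c1cc2ccccc2s1` likewise stops at a limit, and compound 3 gives > 100000 nM in this assay. Two of the three results therefore sit at the same edge of the measurable range (the limit of > 100000 nM in this assay, at which 2 of the 3 values shown sit), which leaves compound 2 as the only point from which a step can be read.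

Compound 4 `NC(=O)c1sc2nc(-c3cccs3)cc(C(F)(F)F)c2c1N` has not yet been measured. It differs from compound 2 in one place (thiophen-2-yl in place of benzyl on an aromatic carbon). Within the data shown here, no pair of measured compounds differs in a comparable way, so nothing measured here says how large a step to expect. Among the measured compounds shown here, with only one number available, the expectation is that the change from compound 2 to compound 4 is modest, possibly within the usual scatter, and a move in either direction cannot be excluded. The estimated step is a 1.5-fold lower number from compound 2 to compound 4 (0.18 log units; within the scatter). Compound 4 is estimated at 20000 nM in this assay, with a likely range from 5000 nM to 100000 nM.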

Compound 4, half-maximal inhibitory concentration: 1600 nM
Compound 4: middle estimate off by 13-fold (1.10 log units), on the high side, and the stated range ends above it.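

The aromatic carbon next to the ring nitrogen and meta to the trifluoromethyl group proves sensitive in this assay: thiophen-2-yl in place of benzyl there gives a 19-fold lower number from compound 2 to compound 4 (1.27 log units; beyond the scatter). Within the data shown here, with compound 2 as the only number, no step could be read at this position, but the shared core now carries two readings, so the group on this carbon is seen to matter strongly. The change bundles several differences, as a six-membered aromatic ring of carbon only gives way to a five-membered aromatic ring with 1 hetero atom, and the group falls from 7 heavy atoms to 5, so this single step cannot separate their contributions.

Nothing among the compounds shown accounts for the size of this step. On these data alone, it remains open whether phenyl, thiophen-3-yl or furan-2-yl on the same carbon would read like thiophen-2-yl, and whether an amine or a longer chain there would be tolerated at all in this assay.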